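Replacing a dimethylphenyl amide with a methylphenyl amide

The source may report more compounds than this note shows. Statements on the series, on what has been measured and on what is new or still open speak of the compounds shown alone.

The series shares one core, an acrylamide attached to a chromone, and is tested in a functional assay (QGY7701 cells, Homo sapiens) for inhibition, read by MTT assay, with a stated time of 48 h; on this read-out lower numbers stand for stronger inhibition and higher numbers for weaker inhibition. Compound 1, `COc1ccc(CNC(=O)/C=C/c2coc3cc(O)ccc3c2=O)cc1`, gives 10000 nM in this assay. Compound 3, `Cc1ccccc1NC(=O)/C=C/c1coc2cc(O)ccc2c1=O`, gives 9320 nM in this assay. Compound 2, `COc1ccc2c(=O)c(/C=C/C(=O)Nc3cc(C)ccc3C)coc2c1`, is the one that reaches only a limit: in this assay compound 2 gives > 100000 nM, which is a limit of the assay and not a number. Among the three values shown, compound 2 is the one that sits at the limit of > 100000 nM in this assay, at which 1 of the 3 values shown sits, so its position can be stated only as weaker than the two numbers measured for compound 1 and compound 3.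

Compound 4, `COc1ccc2c(=O)c(/C=C/C(=O)Nc3ccc(C)cc3)coc2c1`, has not been measured. It differs from compound 2 in one place: 4-methylphenyl in place of 2,5-dimethylphenyl on an amide-type nitrogen. Within the data shown here, no measured pair in this set differs in just this way, so the size of the step can only be estimated. Given that compound 2 has only a limit in this assay, the step from compound 2 to compound 4 is expected to be an at least 2.5-fold lower number from compound 2 to compound 4 (0.39 log units; beyond the scatter), toward stronger inhibition but with broad uncertainty. Compound 4 is therefore expected to give about 40000 nM in this assay, within a range from 8000 nM to 200000 nM.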

Compound 4, half-maximal inhibitory concentration: 39300 nM
The estimate for compound 4 lay 1.0-fold (0.01 log units) above the measured number, within the range that was stated.
By their numbers in this assay, from the lowest: compounds 3 and 1 (each within the scatter of the next); then compound 4. At a limit, above all of these: compound 2.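

In this assay, among these compounds, the change on the amide-type nitrogen from 2,5-dimethylphenyl to 4-methylphenyl gives the first step that can be read at this position: an at least 2.5-fold lower number from compound 2 to compound 4 (0.40 log units; beyond the scatter). The earlier compounds shown here offered no pair differing in one place, so they could not show that this aryl group matters at all on the amide; here, compound 4 gives 39300 nM, a true number on the same core, and the substituent pattern on the phenyl ring is seen to move the read-out. The size of this step remains open upward, because compound 2 stands at a limit of the assay and not at a number: the limit of > 100000 nM in this assay, at which 1 of the 4 values shown sits.

The pair changes both the count of methyl groups and where they stand, so the compounds shown do not tell which of the two carries the step. Also open, from the compounds shown here alone, is how a plain phenyl, a 4-chlorophenyl or a longer alkyl chain on the same amide-type nitrogen would read in this assay, and whether 4-methylphenyl would give a similar step on the core of compound 3.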